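The source may report more compounds than this note shows. Statements on the series, on what has been measured and on what is new or still open speak of the compounds shown alone.

Working notes on the series. For the measured compounds named here, in an ADME assay for permeability, using PAMPA, at pH 7.4 (a higher number here means that the compound crosses the layer faster, a lower number that the compound crosses the layer more slowly), compound 1 (`Cc1cc(NC(=O)Nc2ccccc2OC(F)(F)F)c2ccccc2n1`) gives 1110 10^-6 cm/s, the highest of the three numbers available so far. Compound 3 (`COC(=O)c1ccc(NC(=O)Nc2cc(C)nc3ccccc23)cc1`) gives 448 10^-6 cm/s, and compound 2 (`Cc1cc(NC(=O)Nc2ccc(Cl)c(Cl)c2)c2ccccc2n1`) gives 197 10^-6 cm/s. Both of these lie beyond the scatter from compound 1, so compound 1 stands at the top of this small set.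

The next compound to read is compound 4 (`Cc1cc(NC(=O)Nc2ccccc2C(F)(F)F)c2ccccc2n1`). It carries trifluoromethyl in place of trifluoromethoxy on an aromatic carbon, and the rest of compound 1 stays as it is: trifluoromethyl in place of trifluoromethoxy on an aromatic carbon.

Going by the values given here, no two measured compounds differ in one place only, so the data hold no direct precedent for this change, and the three values give only the general spread of the series. The exchange is small in its count of atoms, so only a modest shift is expected in this assay, most likely none beyond the scatter, with a slight leaning towards a lower number. The starting point for the expectation is compound 1 at 1110 10^-6 cm/s.

The estimated step is a 1.2-fold lower number from compound 1 to compound 4 (0.07 log units; within the scatter), which is expected to stay within the scatter.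

For compound 4 the expected value is 950 10^-6 cm/s, with an estimated range from 450 10^-6 cm/s to 1800 10^-6 cm/s.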

Compound 4, apparent permeability: 945 10^-6 cm/s
Compound 4: the middle estimate sits 1.0-fold (0.00 log units) above what was measured, within the range that was stated.
By their numbers in this assay, from the lowest: compound 2; then compound 3; then compounds 4 and 1 (each within the scatter of the next).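

The series now has its first pair that differs in one place: in this assay the exchange of trifluoromethoxy for trifluoromethyl on an aromatic carbon, ortho to a large group, amounts to a 1.2-fold lower number from compound 1 to compound 4 (0.07 log units; within the scatter) and so cannot be told apart from repeat measurement. At this position, then, removing the oxygen atom along with the hydrogen-bond acceptor counted for the group leaves no readable mark on this read-out, and either of the two fluorinated groups can stand here with the number unchanged as far as the scatter allows. No measurement on hand says why the two groups read alike.

The compounds shown leave open how far this tolerance extends, since both groups at this position are fluorinated and neither an amine, a carboxylic acid nor a longer chain such as ethoxy appears there. They also leave open whether the same exchange would give a similar step at another place on the ring or on a ring carrying further substituents.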